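This account rests on a few compounds, and the source may have more. Where it says the series, first, only, none or still open, it means among the compounds named here.

Compound 3 `CCC(=O)N1CCC(C(=O)N2N=CCC2c2ccccc2)CC1` stands at a limit rather than a number: in an ADME assay on microsomes (Homo sapiens) for metabolic stability (a higher number here means that the compound lasts longer, a lower number that the compound disappears faster), compound 3 gives > 2.75 h, the assay's limit. Among the measured compounds shown here, compound 1 `O=C(c1ccccc1)N1CCC(C(=O)N2N=CCC2c2ccccc2)CC1` is the only member of the set with a plain number, giving 1.72 h in this assay. Compound 2 `O=C(c1cn[nH]c1)N1CCC(C(=O)N2N=CCC2c2ccccc2)CC1` also sits at the limit, giving > 2.75 h in this assay. The steps read an at least 1.5-fold higher number from compound 1 to compound 3 (0.20 log units; that floor lies within the scatter) and an at least 1.5-fold higher number from compound 1 to compound 2 (0.20 log units; that floor lies within the scatter), while a step that the two limits leave unreadable from compound 2 to compound 3; both floors rest on (the limit of > 2.75 h in this assay, at which 2 of the 3 values shown sit).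

Compound 4 `O=C(c1cc[nH]n1)N1CCC(C(=O)N2N=CCC2c2ccccc2)CC1` has not yet been measured. It differs from compound 3 by 1H-pyrazol-3-yl in place of ethyl on a carbonyl carbon. The nearest measured comparison is the step from compound 1 to compound 2, where a different pyrazolyl replaced phenyl on the same carbonyl carbon and the value reached the limit. Since compound 3 already stands at the limit, no direction can be read for the step; compound 4 is expected to stay near the limit, with an estimated step that the limit leaves unreadable from compound 3 to compound 4. Compound 4 is therefore estimated at 3.5 h, between 1.5 h and 8 h, in this assay.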

Compound 4, half-life: > 2.75 h
Compound 4 gave a limit, no number; the forecaster's own chance of this, stated with the estimate: 65%; the middle value lies beyond the limit too.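

On the carbonyl carbon whose other neighbour is the amide-type nitrogen in a ring, 1H-pyrazol-3-yl now joins 1H-pyrazol-4-yl and ethyl at the top of the range in this assay: compound 4 gives > 2.75 h, which is a limit and not a number. Against phenyl, the only readable step is an at least 1.5-fold higher number from compound 1 to compound 4 (0.20 log units; that floor lies within the scatter), so this third replacement adds a floor of the same kind and no firm gain. The steps among compound 2, compound 3 and compound 4 cannot be read, because all three stand at the same limit: the limit of > 2.75 h in this assay, at which 3 of the 4 values shown sit.

Any order among ethyl and the two pyrazolyl groups therefore stays open. Also open, on these data alone, is how a longer chain such as butyl, or a pyridinyl ring, would read on this carbonyl carbon in this assay.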